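This account rests on a few compounds, and the source may have more. Where it says the series, first, only, none or still open, it means among the compounds named here.

Measured in a functional assay on MGC-803 cells (Homo sapiens) for inhibition, read by sulforhodamine B assay; a lower number here means a stronger inhibitor, a higher number a weaker inhibitor:
- Compound 1 `CCc1ccc(NC2=CC(=O)c3nc4n(c3C2=O)[C@H]2OC[C@@H](O)[C@H]2OC4)cc1`: 1290 nM
- Compound 2 `COc1ccccc1NC1=CC(=O)c2nc3n(c2C1=O)[C@H]1OC[C@@H](O)[C@H]1OC3`: 1630 nM
- Compound 3 `COc1ccc(NC2=CC(=O)c3nc4n(c3C2=O)[C@H]2OC[C@@H](O)[C@H]2OC4)cc1`: 1680 nM

These three values cannot be told apart. Compound 3 lies within the scatter of both others, as a 1.3-fold higher number from compound 1 to compound 3 (0.11 log units; within the scatter) and a 1.0-fold higher number from compound 2 to compound 3 (0.01 log units; within the scatter) show. Compound 4 `O=C1C=C(Nc2ccc(I)cc2)C(=O)c2c1nc1n2[C@H]2OC[C@@H](O)[C@H]2OC1` has not yet been measured. It differs from compound 3 by iodo in place of methoxy on an aromatic carbon, with iodo in place of methoxy on an aromatic carbon, para to a large group.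

Within the data shown here, no measured compound carries iodo, so the data do not test that group directly. The closest evidence is the change from compound 1 to compound 3, a 1.3-fold higher number from compound 1 to compound 3 (0.11 log units; within the scatter), where methoxy in place of ethyl stayed within the scatter. Compound 2 adds a 1.3-fold higher number from compound 1 to compound 2 (0.10 log units; within the scatter), also within the scatter. On this evidence, no step beyond the scatter is expected in this assay, though an untested group leaves real uncertainty.

The expected change is a 1.2-fold lower number from compound 3 to compound 4 (0.08 log units; within the scatter).

For compound 4 the estimated value is 1400 nM, with an expected range from 600 nM to 3000 nM.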

Compound 4, half-maximal inhibitory concentration: 1400 nM
For compound 4 middle estimate and measured number coincide at the digits printed; low and high end bracket the measured number.
By their numbers in this assay, from the lowest: compounds 1, 4, 2 and 3 (each within the scatter of the next).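

In this assay, iodo joins ethyl and methoxy at this position, para to a large group, and the steps of a 1.2-fold lower number from compound 3 to compound 4 (0.08 log units; within the scatter) and a 1.1-fold higher number from compound 1 to compound 4 (0.04 log units; within the scatter) leave it indistinguishable from both. The change from the 2-methoxyphenyl compound, a 1.2-fold lower number from compound 2 to compound 4 (0.07 log units; within the scatter), also leaves no readable difference, so a methoxy group of two heavy atoms with a hydrogen-bond acceptor and a single iodine atom without one give the same reading within the scatter. Nothing available explains why these groups read alike.

Across these four compounds, no change on this ring has yet moved the number beyond the scatter. From the compounds shown here alone, how an amine, a carboxylic acid or a longer chain would read at this position remains open, as does whether fluoro or chloro would match iodo.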